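A few compounds are considered here, and "the series" means these few. Any claim that something is new, unique, unknown or untested is made for them only; others in the source may bear on it.

Of the compounds shown here, three have been measured in a functional assay on MGC-803 cells (Homo sapiens) for antiproliferative activity, read by CCK-8 assay, with a stated time of 72 h, tested at 2 uM; on this read-out higher numbers stand for a stronger effect at the one concentration tested and lower numbers for a weaker effect. Compound 1 `Nc1ccccc1NC(=O)c1ccc(CSC(=S)N2CCN(Cc3ccccn3)CC2)cc1` gives 23.4% in this assay, the second highest of the three numbers. Compound 2 `Nc1ccccc1NC(=O)c1ccc(CSC(=S)N2CCN(C(c3ccccc3)c3ccccc3)CC2)cc1` gives 9.8%, which lies beyond the scatter below compound 1. Compound 3 `Nc1ccccc1NC(=O)c1ccc(CSC(=S)N2CCc3ccccc32)cc1` gives 44%, which lies beyond the scatter above compound 1. Compound 4 `Nc1ccccc1NC(=O)c1ccc(CSC(=S)N2CCN(Cc3cccnc3)CC2)cc1` has not yet been measured in this assay. It differs from compound 1 in one place: pyridin-3-yl in place of pyridin-2-yl on a saturated chain carbon bound to an amine nitrogen in a ring. The two compounds share every atom and differ only in how those atoms are joined. Among the compounds with values here, no measured pair shows this kind of change, so there is nothing to set its size from. The expected step is a number 0.4 percentage points lower from compound 1 to compound 4 (within the scatter), none beyond the scatter. The estimate for compound 4 is 23%, with a range from 8% to 40%.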

Compound 4, a percentage reported as inhibition, at one concentration (the size of the read-out at that concentration, not a potency): 37.7%
Compound 4: middle estimate off by 14.7 percentage points, on the low side; the range from low to high includes it.
By their numbers in this assay, from the lowest: compound 2; then compound 1; then compounds 4 and 3 (each within the scatter of the next).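

In this assay, pyridin-3-yl in place of pyridin-2-yl gives a number 14.3 percentage points higher from compound 1 to compound 4 (beyond the scatter) on the same chain carbon. Within the data shown here, this place therefore responds to how the ring atoms are joined alone, with no atom gained or lost, which the earlier compounds, differing from each other in more than one place, could not show. Nothing available explains this step.

Going by these compounds, whether pyridin-4-yl or pyrimidin-5-yl at this place would match compound 4 remains open, as does whether the step would recur on a different core.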